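This account rests on a few compounds, and the source may have more. Where it says the series, first, only, none or still open, it means among the compounds named here.

Three esters of the shared core have been measured in an assay on isolated protein for inhibition of fatty acid synthase (Mus musculus), read by spectrophotometry, using NADPH, with stated times of 30 min and 3 min, in the presence of a further agent that is not named here; a higher number here means a weaker inhibitor, a lower number a stronger inhibitor. Compound 1 `CC1(C)COC(=O)[C@@H]1OC(=O)c1ccc(Cl)cc1` gives 19200 nM in this assay, compound 2 `COc1ccc(C(=O)O[C@H]2C(=O)OCC2(C)C)cc1` gives 13700 nM, and compound 3 `Cc1ccc(C(=O)O[C@H]2C(=O)OCC2(C)C)cc1` gives 17200 nM. Compound 3 holds the second highest of the three numbers; the steps of a 1.1-fold lower number from compound 1 to compound 3 (0.05 log units; within the scatter) and a 1.3-fold higher number from compound 2 to compound 3 (0.10 log units; within the scatter) both lie within the scatter, as does a 1.4-fold lower number from compound 1 to compound 2 (0.15 log units; within the scatter). Compound 4 `CCCCc1ccc(C(=O)O[C@H]2C(=O)OCC2(C)C)cc1` differs from compound 3 by propyl in place of hydrogen on a saturated chain carbon bound to an aromatic carbon. For the measured compounds named here, no measured step concerns a change of this kind; the three steps, all swaps of the substituent on an aromatic carbon, stayed within the scatter, so no step beyond the scatter is expected in this assay. Compound 4 is therefore expected to give 15000 nM in this assay, between 5000 nM and 45000 nM. The expected step is a 1.1-fold lower number from compound 3 to compound 4 (0.06 log units; within the scatter).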

Compound 4, half-maximal inhibitory concentration: 27700 nM
Estimate against measurement, compound 4: 1.8-fold (0.27 log units) below; the measured number falls inside the stated range.
By their numbers in this assay, from the lowest: compounds 2, 3, 1 and 4 (each within the scatter of the next, the first and the last beyond it).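

Propyl in place of hydrogen on a saturated chain carbon bound to an aromatic carbon gives a 1.6-fold higher number from compound 3 to compound 4 (0.21 log units; within the scatter) in this assay, and butyl in place of chloro gives a 1.4-fold higher number from compound 1 to compound 4 (0.16 log units; within the scatter), so neither change moves the number past the scatter. For the compounds shown here, only butyl in place of methoxy gives a 2.0-fold higher number from compound 2 to compound 4 (0.31 log units; beyond the scatter), a modest step that is the first to pass the scatter. No measurement shown offers an explanation for these steps.

The compounds shown leave open how a longer chain at this place would read. They also leave open whether an amine or a carboxylic acid there would read differently from butyl.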